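Same atoms joined differently in compound 3

A few compounds are considered here, and "the series" means these few. Any claim that something is new, unique, unknown or untested is made for them only; others in the source may bear on it.

For the measured compounds named here, in a physicochemical assay for solubility, using the shake flask method, in phosphate buffer, with a stated time of 20 h, at pH 6.5 (a lower number here means a less soluble compound, a higher number a more soluble compound), compound 2 (`C[S+]([O-])c1ccc(-c2cnc3ccc(Nc4cccc([S+](C)[O-])c4)nn23)cc1`) gives 190000 nM as the higher of the two numbers so far, and compound 1 (`C[S+]([O-])c1ccc(-c2cnc3ccc(Nc4cccc(S(C)(=O)=O)c4)nn23)cc1`) gives 20000 nM as the lower. The change to compound 3 (`C[S+]([O-])c1ccc(Nc2ccc3ncc(-c4ccc([S+](C)[O-])cc4)n3n2)cc1`) is a group of 9 heavy atoms (7 carbon, 1 oxygen, 1 sulfur; one six-membered aromatic ring of carbon only) in place of a group of 9 heavy atoms (7 carbon, 1 oxygen, 1 sulfur; one six-membered aromatic ring of carbon only), on a nitrogen on an aromatic ring and the same atoms are only joined differently. Going by the values given here, the only measured step (a 9.5-fold higher number from compound 1 to compound 2 (0.98 log units; beyond the scatter)) exchanged a different group, so it guides this change only loosely. A small drop is expected (a 1.9-fold lower number from compound 2 to compound 3 (0.28 log units; within the scatter)) and it should stay within the scatter. In this assay the estimated value for compound 3 is 100000 nM with a likely range from 30000 nM to 300000 nM as its expected span.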

Compound 3, solubility: 195000 nM
Compound 3: the middle estimate sits 2.0-fold (0.29 log units) below what was measured; the measured number falls inside the stated range.
By their numbers in this assay, from the lowest: compound 1; then compounds 2 and 3 (each within the scatter of the next).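

In this assay, rejoining the same atoms within the group of 9 heavy atoms on a nitrogen on an aromatic ring gives a 1.0-fold higher number from compound 2 to compound 3 (0.01 log units; within the scatter), so the two compounds cannot be told apart. The earlier step changed the atoms of a group, whereas this one shows that a different joining of identical atoms at this place can leave the number within the scatter. No measurement shown here offers an explanation for this result. Still open, from the compounds shown here alone, is how the number in this assay would respond to an amine or a carboxylic acid on this ring in place of the sulfur-bearing group.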